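The source may report more compounds than this note shows. Statements on the series, on what has been measured and on what is new or still open speak of the compounds shown alone.

Measured in a functional assay on DU-145 cells (Homo sapiens) for cytotoxicity, read by MTT assay; a lower number here means a stronger inhibitor, a higher number a weaker inhibitor:

- compound 1 `CC(C)=CC[C@@H](OC(=O)CCO)C1=CC(=O)c2c(O)ccc(O)c2C1=O`: 55300 nM
- compound 2 `CC(C)=CC[C@@H](OC[C@@H](C)O)C1=CC(=O)c2c(O)ccc(O)c2C1=O`: 14300 nM
- compound 3 `CCC(O)CO[C@H](CC=C(C)C)C1=CC(=O)c2c(O)ccc(O)c2C1=O`: 16400 nM

Compound 3 lies within the scatter of compound 2 , and both have clearly lower numbers than compound 1 . The gap on that side is a 3.4-fold lower number from compound 1 to compound 3 (0.53 log units; beyond the scatter).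

The next compound is compound 4 `CC(C)=CC[C@@H](OCC(C)O)C1=CC(=O)c2c(O)ccc(O)c2C1=O`, and the change is hydrogen in place of methyl on a saturated chain carbon, two bonds along the chain from an oxygen on a saturated carbon. This shortens 2-hydroxybutyl to 2-hydroxypropyl.

The measured step that bears most directly on this is a 1.1-fold higher number from compound 2 to compound 3 (0.06 log units; within the scatter), which exchanges 1-hydroxyethyl for 1-hydroxypropyl and so runs the same way in reverse. Among the measured compounds shown here, the larger steps, a 3.9-fold lower number from compound 1 to compound 2 (0.59 log units; beyond the scatter) and the one to compound 3 , replace (2-hydroxyethyl)carbonyl and say little about this change.

No shift beyond the scatter is therefore expected in this assay, and the estimated step is a 1.1-fold lower number from compound 3 to compound 4 (0.04 log units; within the scatter).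

Compound 4 is expected at 15000 nM, with an estimated range from 8500 nM to 27000 nM.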

Compound 4, half-maximal inhibitory concentration: 16100 nM
For compound 4 the middle estimate is 1.1-fold (0.03 log units) below the measured one, within the range that was stated.
By their numbers in this assay, from the lowest: compounds 2, 4 and 3 (each within the scatter of the next); then compound 1.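

In this assay, shortening 2-hydroxybutyl to 2-hydroxypropyl gives a 1.0-fold lower number from compound 3 to compound 4 (0.01 log units; within the scatter), so removing this methyl from a saturated chain carbon, two bonds along the chain from an oxygen on a saturated carbon, has no readable effect in a direct comparison. Replacing (2-hydroxyethyl)carbonyl with 2-hydroxypropyl gives a 3.4-fold lower number from compound 1 to compound 4 (0.54 log units; beyond the scatter), placing compound 4 with compound 2 and compound 3 on the low side of compound 1. The remaining comparison, a 1.1-fold higher number from compound 2 to compound 4 (0.05 log units; within the scatter), shows no readable effect from the one feature that separates the pair: the fact that one of compounds 2 and 4 is drawn with a defined configuration and the other without, at the place where they differ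

The compounds shown do not settle how the opposite defined configuration at this stereocentre would read. Also open, from the compounds shown here alone, is whether an amine, a carboxylic acid or a chain longer than 2-hydroxybutyl would move the number.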